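This account rests on a few compounds, and the source may have more. Where it says the series, first, only, none or still open, it means among the compounds named here.

Measured so far in an assay on Sf9 cells for inhibition of serine/threonine-protein kinase 4 (Homo sapiens), read by luminescence and ADP-Glo, with a stated time of 1 h, in the presence of a further agent that is not named here; on this read-out higher numbers stand for weaker inhibition and lower numbers for stronger inhibition:

compound 1 `CCCC1C(=O)N(C)c2cnc(Nc3ccc(S(N)(=O)=O)cc3)nc2N1C` gives 206 nM
compound 2 `CC(C)C1C(=O)N(C)c2cnc(Nc3ccc(S(N)(=O)=O)cc3)nc2N1C` gives 254 nM
compound 3 `CN1C(=O)C(c2ccccc2Cl)N(C)c2nc(Nc3ccc(S(N)(=O)=O)cc3)ncc21` gives 129 nM

Compound 2 has the highest of the three numbers, though none of the gaps reaches beyond the scatter: a 1.2-fold higher number from compound 1 to compound 2 (0.09 log units; within the scatter) and a 2.0-fold lower number from compound 2 to compound 3 (0.29 log units; within the scatter). Compound 4 `COc1ccccc1C1C(=O)N(C)c2cnc(Nc3ccc(S(N)(=O)=O)cc3)nc2N1C` differs from compound 2 in one place: 2-methoxyphenyl in place of isopropyl on a saturated ring carbon. Among the measured compounds shown here, the steps that bear on this are a 2.0-fold lower number from compound 2 to compound 3 (0.29 log units; within the scatter) and a 1.6-fold lower number from compound 1 to compound 3 (0.20 log units; within the scatter), both placing an aromatic ring on that saturated ring carbon and both staying within the scatter. For compound 4 the same kind of change is therefore expected to give at most a small drop in the number in this assay, a 1.5-fold lower number from compound 2 to compound 4 (0.17 log units; within the scatter). Compound 4 is estimated at 170 nM, within 90 nM to 330 nM.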

Compound 4, half-maximal inhibitory concentration: 251 nM
Compound 4: the middle estimate sits 1.5-fold (0.17 log units) below what was measured, and the stated range covers the measured number.
By their numbers in this assay, from the lowest: compounds 3, 1, 4 and 2 (each within the scatter of the next).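

In this assay, replacing the alkyl group on the saturated ring carbon with 2-methoxyphenyl stays within the scatter from either alkyl compound (a 1.0-fold lower number from compound 2 to compound 4 (0.01 log units; within the scatter); a 1.2-fold higher number from compound 1 to compound 4 (0.09 log units; within the scatter)). Methoxy in place of chloro on an aromatic carbon of that ring, a change the earlier compounds did not include, also stays within the scatter (a 1.9-fold higher number from compound 3 to compound 4 (0.29 log units; within the scatter)). No supporting evidence accounts for how close these numbers lie.

The compounds shown leave open whether an amine, a carboxylic acid or a longer chain on the saturated ring carbon would give a step beyond the scatter. They also leave open how an unsubstituted phenyl would compare.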